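A second fluorine on the fluorinated phenyl ring

The compounds below may be only part of what the source reports. "The series", "measured", "known", "first", "only" and "open" are said of these compounds alone.

Compound 1 `O=C(O)Cc1sc(C(c2ccccc2)c2ccccc2)nc1-c1ccccc1` is the starting point. In an in vitro assay on HEK385-7 cells for displacement of a labelled ligand from prostaglandin D2 receptor 2 (Homo sapiens) (on this read-out higher numbers stand for weaker inhibition and lower numbers for stronger inhibition), compound 1 gives 570 nM. Compound 2 `O=C(O)Cc1sc(C(c2ccccc2)c2ccccc2)nc1-c1cccc(F)c1` differs from it by fluoro in place of hydrogen on an aromatic carbon, and in this assay compound 2 gives 2.9 nM, which is a 200-fold lower number from compound 1 to compound 2 (2.29 log units; beyond the scatter). Compound 3 `O=C(O)Cc1sc(C(c2ccc(F)cc2)c2ccc(F)cc2)nc1-c1cccc(F)c1` carries fluoro on two further rings as well; the difference between its core and that of compound 1 is not broken down here. In this assay compound 3 gives 1.4 nM, the lowest number of the three.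

Compound 4 `O=C(O)Cc1sc(C(c2ccc(F)cc2)c2ccc(F)cc2)nc1-c1cc(F)cc(F)c1` is not yet measured. It differs from compound 3 by fluoro in place of hydrogen on an aromatic carbon. Among the measured compounds shown here, this is the same kind of change as the one from compound 1 to compound 2, but here the place is also meta to a fluoro group. Because the first fluoro on this ring produced a 200-fold lower number from compound 1 to compound 2 (2.29 log units; beyond the scatter), a further gain is expected, though a much smaller one, since compound 3 already stands very low. For compound 4 the expected step in this assay is a 1.6-fold lower number from compound 3 to compound 4 (0.19 log units; within the scatter), giving an estimate of 0.9 nM, between 0.3 nM and 3 nM.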

Compound 4, half-maximal inhibitory concentration: 35 nM
The estimate for compound 4 lay 39-fold (1.59 log units) below the measured number; measured number above the stated range.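

In this assay, adding a second fluoro to this ring gives a 25-fold higher number from compound 3 to compound 4 (1.40 log units; beyond the scatter), so the large gain seen with the first fluoro does not carry over to the core of compound 3. Set side by side, the same kind of change moves the number in opposite directions on the two cores, and the gap is too large to be scatter: the same change on two cores in this assay, a 200-fold lower number (2.29 log units; beyond the scatter) from compound 1 to compound 2 and a 25-fold higher number (1.40 log units; beyond the scatter) from compound 3 to compound 4, 4900-fold (3.69 log units) apart, beyond the scatter of two such steps This shows that the effect of this change in the series depends on the core that carries it, but not which difference between the cores matters: the new fluoro in compound 4 is meta to a fluoro group, and compound 3 also carries fluoro on two further rings.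

The compounds shown leave open whether 3-fluorophenyl to 3,5-difluorophenyl would also raise the number on the core of compound 2, which lacks those two further fluoro groups. They also leave open how chloro, methoxy or a nitrile would behave at the same place.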